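This account rests on a few compounds, and the source may have more. Where it says the series, first, only, none or still open, it means among the compounds named here.

Working notes on the series. Compound 1 `COc1ccc(S(=O)(=O)N2CCC3(CC2)OOC2(CCCC2)OO3)cc1`, compound 2 `COc1ccc(S(=O)(=O)N2CCC3(CC2)OOC2(CCCCC2)OO3)cc1` and compound 3 `O=S(=O)(c1ccc(F)cc1)N1CCC2(CC1)OOC1(CCCC1)OO2` have each been run in a functional assay on Huh-7 cells (Homo sapiens) for cytotoxicity, read by MTT assay, with a stated time of 72 h; a higher number here means that more compound is tolerated, a lower number that less compound is tolerated. Compound 4 `O=S(=O)(c1ccc(F)cc1)N1CCC2(CC1)OOC1(CCCCC1)OO2` has not yet been run there.

In this assay compound 1 gives > 100 ug/mL, which is a limit of the assay and not a number. Compound 2 likewise gives only a limit in this assay, namely > 100 ug/mL. For compound 3 the result in this assay is again a limit, > 100 ug/mL.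

The change from compound 1 to compound 3 is fluoro in place of methoxy on an aromatic carbon. Its size in this assay cannot be read, a step that the two limits leave unreadable from compound 1 to compound 3, because of the limit of > 100 ug/mL in this assay, at which 3 of the 3 values shown sit.

How the core of compound 2 differs from the core of compound 1 is not broken down here. Compound 4 stands to compound 2 as compound 3 stands to compound 1: the change is fluoro in place of methoxy on an aromatic carbon, the same change as between compound 1 and compound 3, with the same surroundings at the place of the change.

The expected step that the limit leaves unreadable from compound 2 to compound 4 in this assay rests on compound 2 sitting at a limit, > 100 ug/mL. The unreadable step that the two limits leave unreadable from compound 1 to compound 3 gives no sign in either direction. Compound 4 is therefore expected to give about 150 ug/mL in this assay, with a likely range from 80 ug/mL to 400 ug/mL, and most probably only a limit will be reported.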

Compound 4, half-maximal cytotoxic concentration: > 100 ug/mL
Compound 4: a limit, no number; the forecaster's own chance of this, stated with the estimate: 85%; the middle value lies beyond the limit too.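

In this assay compound 4 gives > 100 ug/mL, which is a limit of the assay and not a number. The step from compound 2 to compound 4 therefore cannot be read: the limit of > 100 ug/mL in this assay, at which 4 of the 4 values shown sit.

The compounds shown leave open whether fluoro in place of methoxy, or the difference between the core of compound 1 and the core of compound 2, changes the result in this assay at all.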